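Phenyl to pyridin-3-yl on the thioether side chain

The source may hold more compounds than are shown below. What is called first, only, known or untested is meant among the compounds shown, and "the series" means these compounds.

Compound 1 `CC(Sc1nc2nn(C3COC3)cc2c(=O)n1-c1ccccc1)c1ccccc1` gives 109 nM in an assay on isolated protein for inhibition of Retinaldehyde dehydrogenase 3 (Homo sapiens); a higher number here means a weaker inhibitor, a lower number a stronger inhibitor. Among the three measured compounds it stands second highest; its nearest neighbour is compound 2 `CC(Sc1nc2nn(C3(C)COC3)cc2c(=O)n1-c1ccccc1)c1ccccc1` at 50 nM, and the furthest is compound 3 `C#Cc1ccc(-n2c(SC(C)c3ccccc3)nc3c(cnn3C)c2=O)cc1` at 520 nM. Among the compounds with values here, the only single-place step recorded, a 2.2-fold lower number from compound 1 to compound 2 (0.34 log units; beyond the scatter), concerns methyl in place of hydrogen on a saturated ring carbon and does not touch the side chain changed here. Compound 3 differs from compound 1 in more than one place, so its value cannot be tied to any one change.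

The unmeasured compound 4 `CC(Sc1nc2nn(C3COC3)cc2c(=O)n1-c1ccccc1)c1cccnc1` differs from compound 1 by pyridin-3-yl in place of phenyl on a saturated chain carbon bound to a saturated chain carbon and a sulfur. Within the data shown here, no measured step bears on this change; the series gives no direct precedent for swapping the aryl ring on the saturated chain carbon bound to a saturated chain carbon and a sulfur. The expectation is therefore for a step within or near the usual scatter, a 1.5-fold higher number from compound 1 to compound 4 (0.17 log units; within the scatter), with a modest chance of a weaker number. Compound 4 is estimated at 160 nM, with a range of 50 nM to 500 nM in this assay.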

Compound 4, half-maximal inhibitory concentration: 250 nM
Compound 4: the middle estimate sits 1.6-fold (0.19 log units) below what was measured; the range from low to high includes it.
By their numbers in this assay, from the lowest: compound 2; then compound 1; then compound 4; then compound 3.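

The side chain now has a measured step: in this assay pyridin-3-yl in place of phenyl on a saturated chain carbon bound to a saturated chain carbon and a sulfur gives a 2.3-fold higher number from compound 1 to compound 4 (0.36 log units; beyond the scatter) and so costs a modest amount of potency. This position therefore responds to a single ring atom, as the swap keeps the count of six heavy atoms and adds one hydrogen-bond acceptor, and of these two rings phenyl gives the lower number. No available measurement accounts for this step.

On these data alone, it remains open whether pyridin-4-yl or pyridin-2-yl at this carbon would give a similar number, or whether a fluorine or a methoxy group on the phenyl ring would shift it. Also open, as far as these compounds go, is whether the step from methyl on the saturated ring carbon would hold alongside pyridin-3-yl.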